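This account rests on a few compounds, and the source may have more. Where it says the series, first, only, none or still open, it means among the compounds named here.

Measured compounds in an ADME assay on THP-1 cells (Homo sapiens) for cytotoxicity; on this read-out lower numbers stand for stronger inhibition and higher numbers for weaker inhibition:

compound 1 `COc1ccccc1-c1nnc(-c2ccc(C(=O)N/N=C/c3ccccc3[N+](=O)[O-])cc2)o1`: 161000 nM
compound 2 `COc1ccccc1-c1nnc(-c2ccc(C(=O)N/N=C/c3ccc(F)cc3)cc2)o1`: 427000 nM
compound 3 `COc1ccc(O)c(/C=N/NC(=O)c2ccc(-c3nnc(-c4ccccc4OC)o3)cc2)c1`: 303000 nM

All three share the same core and differ only in the aryl group on a carbon with a double bond to nitrogen. Compound 3 sits in the middle of the three numbers, but its distance to each neighbour is within the scatter: the change a 1.4-fold lower number from compound 2 to compound 3 (0.15 log units; within the scatter) and the change a 1.9-fold higher number from compound 1 to compound 3 (0.27 log units; within the scatter) are both too small to count as real movement. Only the change a 2.7-fold higher number from compound 1 to compound 2 (0.42 log units; beyond the scatter) reaches beyond the scatter, and even that is modest.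

Compound 4 `COc1ccccc1-c1nnc(-c2ccc(C(=O)N/N=C/c3ccccn3)cc2)o1` is the next member of this set and has not been measured. The difference from compound 3 is pyridin-2-yl in place of 2-hydroxy-5-methoxyphenyl on a carbon with a double bond to nitrogen. The three measured compounds show that swapping the aryl group at this position, whether for 4-fluorophenyl, 2-nitrophenyl or 2-hydroxy-5-methoxyphenyl, moved the number in this assay by at most a modest amount and usually not beyond the scatter. A further swap to pyridin-2-yl is therefore expected to give a step of a 1.1-fold lower number from compound 3 to compound 4 (0.05 log units; within the scatter) that stays within the scatter, with no clear direction. For compound 4 the expected value in this assay is 270000 nM, with a range from 110000 nM to 650000 nM.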

Compound 4, half-maximal inhibitory concentration: 67000 nM
Compound 4: middle estimate off by 4.0-fold (0.61 log units), on the high side; the measured number lies below the stated range.
By their numbers in this assay, from the lowest: compound 4; then compounds 1, 3 and 2 (each within the scatter of the next, the first and the last beyond it).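

In this assay, within the data shown here, pyridin-2-yl on a carbon with a double bond to nitrogen is the first group to stand clearly apart from all the others, with a 4.5-fold lower number from compound 3 to compound 4 (0.66 log units; beyond the scatter) and a 6.4-fold lower number from compound 2 to compound 4 (0.80 log units; beyond the scatter) and also a 2.4-fold lower number from compound 1 to compound 4 (0.38 log units; beyond the scatter) as the three steps to it. Among the earlier compounds only one step reached beyond the scatter, so this position can shift the number further than they suggested, and compound 4 now has the lowest number of the set, which on this read-out means the strongest inhibition. Compound 4 is also the only one here with a hetero atom in this ring, but that is a link seen in a single compound, and no supporting data explain the drop.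

With only one such ring shown, it remains open whether the ring nitrogen matters or whether losing the substituents of the other aryl groups would do the same, which plain phenyl at this position could test. Also open, from the compounds shown here alone, is how an aryl group carrying an amine or a carboxylic acid would behave here, and whether the step holds on a changed core.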